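Acetamide to Phenylurea on a Shared Core: Expected Binding

The source may hold more compounds than are shown below. What is called first, only, known or untested is meant among the compounds shown, and "the series" means these compounds.

Measured compounds:
- Compound 1 `COc1ccc(-n2cc3nc(Cc4ccccc4)nc(N)c3n2)cc1` gives 40% in an assay on CHO cells for displacement of a labelled ligand from adenosine receptor A1 (Homo sapiens), read by scintillation counting, with a stated time of 120 min, tested at 1 uM; on this read-out higher numbers stand for more inhibition at the one concentration tested (going by the name of the read-out) and lower numbers for less inhibition
- Compound 2 `CC(=O)Nc1nc(C)nc2cn(-c3ccccc3)nc12` gives 25% in this assay
- Compound 3 `Cc1nc(N(C(=O)c2ccccc2)C(=O)c2ccccc2)c2nn(-c3ccccc3)cc2n1` gives 6% in this assay

Among these three numbers, compound 2 stands second highest. Its nearest neighbour is compound 1, whose number lies higher by a margin beyond the usual scatter, and its furthest is compound 3, whose number lies lower, again beyond the scatter. Compound 4 `Cc1nc(NC(=O)Nc2ccccc2)c2nn(-c3ccccc3)cc2n1` has not yet been measured in this assay. It differs from compound 2 in one place: anilino in place of methyl on a carbonyl carbon. The methyl on the carbonyl carbon gives way to an anilino, so the group attached to the amide-type nitrogen grows from a small acetamide into a phenylurea.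

For the measured compounds named here, no measured pair here shows the effect of this exact change, so the expectation rests only on where compound 2 sits between compound 1 and compound 3. A step within the scatter, or a modest fall toward compound 3, seems most plausible, rather than a rise toward compound 1. Compound 4 is therefore expected to give about 20% in this assay, within a range from 5% to 38%, a change estimated as a number 5 percentage points lower from compound 2 to compound 4 (within the scatter).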

Compound 4, a percentage reported as inhibition, at one concentration (the size of the read-out at that concentration, not a potency): 1%
Compound 4: middle estimate off by 19 percentage points, on the high side; the whole stated range lies above it.
By their numbers in this assay, from the lowest: compounds 4 and 3 (each within the scatter of the next); then compound 2; then compound 1.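

In this assay, for the compounds shown here, putting an anilino in place of the methyl on the carbonyl carbon gives a number 24 percentage points lower from compound 2 to compound 4 (beyond the scatter), the first direct one-place comparison in this set, and it shows that the group at this position affects the read-out. The small acetamide of compound 2 keeps some inhibition at the one concentration tested, whereas this phenylurea change does not preserve it and instead leaves compound 4 with very little. The data offer no measured explanation for this loss, and no direct information bears on its cause.

The change adds a six-membered aromatic ring and a hydrogen-bond donor in one step, so these compounds cannot show which part of the anilino goes with the lower number. A methylurea would carry the urea nitrogen without the phenyl ring, and a single benzoyl group on the amide-type nitrogen would carry a phenyl ring without the urea nitrogen, so the two would help to pull these contributions apart on the shared core.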